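Working notes: a chloro analogue of compound 1

The compounds below may be only part of what the source reports. "The series", "measured", "known", "first", "only" and "open" are said of these compounds alone.

Measured so far:
compound 1, `CC(C)c1cc(Cn2ccc3cc(OCC(=O)O)ccc32)ccc1O`: 13.5 nM in an assay on HeLa cells for displacement of a labelled ligand from thyroid hormone receptor alpha (Homo sapiens); on this read-out lower numbers stand for stronger inhibition and higher numbers for weaker inhibition
compound 2, `Cc1cn(Cc2ccc(O)c(C(C)C)c2)c2ccc(OCC(=O)O)cc12`: 7.74 nM in this assay

For the measured compounds named here, of the two numbers in this assay, that of compound 1 is the higher one, but the single measured step, a 1.7-fold lower number from compound 1 to compound 2 (0.24 log units; within the scatter), lies within the scatter, so the two compounds cannot be told apart on this read-out. Compound 3, `CC(C)c1cc(Cn2ccc3cc(OCC(=O)O)cc(Cl)c32)ccc1O`, differs from compound 1 by chloro in place of hydrogen on an aromatic carbon. Going by the values given here, no measured step concerns this place or this group: the only step in hand is the methyl substitution from compound 1 to compound 2, and that one stayed within the scatter. Among the compounds with values here, the change from hydrogen to chloro is small in heavy-atom count and adds no donor, acceptor or charge, and nothing among the measured compounds indicates a shift in either direction. The expectation for compound 3 is therefore a step of a 1.0-fold lower number from compound 1 to compound 3 (0.02 log units; within the scatter), that is, none beyond the scatter. Compound 3 is estimated at 13 nM in this assay, with a range from 5 nM to 35 nM.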

Compound 3, inhibition constant: 0.35 nM
Compound 3: the middle estimate sits 37-fold (1.57 log units) above what was measured, outside the stated range (below it).
By their numbers in this assay, from the lowest: compound 3; then compounds 2 and 1 (each within the scatter of the next).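

For the compounds shown here, on the aromatic carbon that is ortho to a fused ring and meta to the carboxymethoxy group, chloro in place of hydrogen gives a 39-fold lower number from compound 1 to compound 3 (1.59 log units; beyond the scatter) in this assay, so this position of the core responds strongly to substitution, a sensitivity of which the only earlier step, a 1.7-fold lower number from compound 1 to compound 2 (0.24 log units; within the scatter), at a different place, gave no sign. The change that produces this large step is small by count: 1 heavy atom enters, with 0 hydrogen-bond donors, 0 hydrogen-bond acceptors and no net charge, so in this series a step of this size does not require a large added group. No measured information is available that bears on why this single replacement has so large an effect.

The compounds shown leave open whether the step belongs to chloro specifically or would also appear with fluoro, bromo, methyl or methoxy on the same aromatic carbon. They also leave open whether chloro at this carbon would give a step of similar size on the core of compound 2, which already carries the methyl group.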